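The source may report more compounds than this note shows. Statements on the series, on what has been measured and on what is new or still open speak of the compounds shown alone.

Of the compounds shown here, three that share one core have been measured in a functional assay on MCF7 cells (Homo sapiens) for cytotoxicity, read by MTT assay, with a stated time of 72 h; a lower number here means a stronger inhibitor, a higher number a weaker inhibitor. Compound 1 `CC(C)=C1C(=O)N(c2ccc(Cl)cc2)N(c2ccc(Cl)cc2)C1=O` gives 39600 nM. Compound 3 `CC(=C1C(=O)N(c2ccc(Cl)cc2)N(c2ccc(Cl)cc2)C1=O)c1ccc(O)cc1` gives 76500 nM. Among the measured compounds shown here, the only step between measured compounds that differ in a single place, a 1.9-fold higher number from compound 1 to compound 3 (0.29 log units; within the scatter), therefore did not move the number beyond the scatter. Compound 2 `O=C1C(=Cc2cccc(Cl)c2)C(=O)N(c2ccc(Cl)cc2)N1c1ccc(Cl)cc1` gives 18300 nM, the lowest number of the three, and since its steps to both other compounds lie beyond the scatter, it is the strongest inhibitor of the measured set; compound 1 stands closest to it and compound 3 furthest away.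

Compound 4 `O=C1C(=Cc2c[nH]c3ccccc23)C(=O)N(c2ccc(Cl)cc2)N1c1ccc(Cl)cc1` has not yet been measured. It differs from compound 2 in one place: 1H-indol-3-yl in place of 3-chlorophenyl on a double-bonded chain carbon bound to a double-bonded ring carbon. For the measured compounds named here, no measured step concerns a change of this kind; the single measured step, a 1.9-fold higher number from compound 1 to compound 3 (0.29 log units; within the scatter), swaps a different pair of groups and stayed within the scatter, so it offers no direction for the present exchange. With nothing in the data pointing either way, the expected step, a 1.1-fold higher number from compound 2 to compound 4 (0.04 log units; within the scatter), is none beyond the scatter. Compound 4 is accordingly estimated at 20000 nM, with an expected range from 7000 nM to 60000 nM.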

Compound 4, half-maximal inhibitory concentration: 34200 nM
Compound 4: middle estimate off by 1.7-fold (0.23 log units), on the low side; measured number inside the range.
By their numbers in this assay, from the lowest: compounds 2, 4, 1 and 3 (each within the scatter of the next, the first and the last beyond it).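

On a double-bonded chain carbon bound to a double-bonded ring carbon, 1H-indol-3-yl takes the place of 3-chlorophenyl in this assay with a 1.9-fold higher number from compound 2 to compound 4 (0.27 log units; within the scatter). Among the compounds shown here, this is the first measured exchange at this place, and it is a sizeable one: the chlorine goes, while a five-membered aromatic ring with a nitrogen and a hydrogen-bond donor comes in, yet the number does not move beyond the scatter, so compound 2 and compound 4 cannot be put in order. No measurement at hand accounts for this result.

For the compounds shown here, with only this pair, it remains open whether other groups at this place would also stay within the scatter, or whether an amine or a carboxylic acid there would move the number further. Also open, going by these compounds, is what the chlorine and the indole hydrogen each contribute, which a plain phenyl or 1-methyl-1H-indol-3-yl at the same place could help to separate.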